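Dropping both chlorines: an expectation for compound 3

The source may hold more compounds than are shown below. What is called first, only, known or untested is meant among the compounds shown, and "the series" means these compounds.

Measured compounds:
compound 1 `COc1ccc(-c2nc(C)c(C(=O)CSc3nc(-c4ccc(Cl)cc4)c(C#N)c(=O)[nH]3)s2)cc1` — 2.85%
compound 2 `COc1ccc(-c2nc(C)c(C(=O)CSc3nc(-c4ccc(Cl)c(Cl)c4)c(C#N)c(=O)[nH]3)s2)cc1` — 31.1%

Compound 2 stands highest of the two numbers in a functional assay on U-87MG ATCC cells for antiproliferative activity against U-87 MG (Homo sapiens), read by MTT assay, with a stated time of 48 h, tested at 100 uM; on this read-out lower numbers stand for a stronger effect and higher numbers for a weaker effect at the one concentration tested; its nearest neighbour is compound 1, whose value is lower by a number 28.3 percentage points higher from compound 1 to compound 2 (beyond the scatter). Compound 3 `COc1ccc(-c2nc(C)c(C(=O)CSc3nc(-c4ccccc4)c(C#N)c(=O)[nH]3)s2)cc1` is not yet measured. It differs from compound 2 in one place: phenyl in place of 3,4-dichlorophenyl on an aromatic carbon.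

Within the data shown here, only one measured step bears on this change. Going from compound 1 to compound 2 put a chloro in place of hydrogen on an aromatic carbon and raised the number by a number 28.3 percentage points higher from compound 1 to compound 2 (beyond the scatter), a modest move beyond the scatter. The step from compound 2 to compound 3 runs the other way, removing chlorine rather than adding it, and removes two chlorines rather than one. So a lower number is expected for compound 3 in this assay, of a size at least comparable to that step.

Compound 3 is therefore estimated at 12%, with a likely range from 0% to 40%, which means an expected step of a number 19.1 percentage points lower from compound 2 to compound 3 (beyond the scatter) from compound 2 to compound 3.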

Compound 3, a percentage reported as activity, at one concentration (the size of the read-out at that concentration, not a potency): 10.9%
The estimate for compound 3 lay 1.1 percentage points above the measured number; low and high end bracket the measured number.
By their numbers in this assay, from the lowest: compounds 1 and 3 (each within the scatter of the next); then compound 2.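

In this assay, replacing 3,4-dichlorophenyl with phenyl gave a number 20.2 percentage points lower from compound 2 to compound 3 (beyond the scatter), so the change at this position on the ring with two nitrogens can be read in both directions: adding chlorine to compound 1 and removing both chlorines from compound 2 each moved the number beyond the scatter. Among these compounds, the further step, a number 8.1 percentage points higher from compound 1 to compound 3 (within the scatter), shows that the single chloro of compound 1 and the hydrogen in its place cannot be told apart here, which leaves compound 2, with its two chlorines, as the only one of the three that stands apart, with the weaker effect. Nothing measured on these compounds explains this difference.

Going by these compounds, it remains open whether other groups on this phenyl, such as a methoxy group, an amine or a bromine, would read like the hydrogen and single chloro or like the 3,4-dichlorophenyl. On these data alone, each number gives the size of the effect at one concentration only, and whether the three compounds would show a stronger or weaker effect in the same order at other concentrations also stays open.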